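Taking the benzyl group off compound 2

The source may hold more compounds than are shown below. What is called first, only, known or untested is meant among the compounds shown, and "the series" means these compounds.

Measured in an ADME assay on THP-1 cells (Homo sapiens) for cytotoxicity, read by MTT assay, with a stated time of 72 h; on this read-out lower numbers stand for stronger inhibition and higher numbers for weaker inhibition:
Compound 1 `COc1ccc(/C=C/C(=O)c2c(O)c3ccccc3n(Cc3ccccc3)c2=O)cc1OC`: 28700 nM
Compound 2 `Cc1ccccc1/C=C/C(=O)c1c(O)c2ccccc2n(Cc2ccccc2)c1=O`: 45700 nM
Compound 3 `O=C(/C=C/c1ccc(C(F)(F)F)cc1)c1c(O)c2ccccc2[nH]c1=O`: > 50000 nM (a limit of the assay, not a number)

Within the data shown here, only two of these readings are true numbers, and compound 2 at 45700 nM cannot be told apart from compound 1 at 28700 nM. The next compound is compound 4 `Cc1ccccc1/C=C/C(=O)c1c(O)c2ccccc2[nH]c1=O`, which has hydrogen in place of benzyl on an aromatic nitrogen.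

Among the measured compounds shown here, no measured step makes this exact change. For the measured compounds named here, the one measured step, a 1.6-fold higher number from compound 1 to compound 2 (0.20 log units; within the scatter), concerns the other end of the molecule and shows that swapping 3,4-dimethoxyphenyl for 2-methylphenyl leaves the reading within the scatter. The nearest hint is compound 3, which also has hydrogen on that aromatic nitrogen. Compound 3 reads > 50000 nM, which is a limit. On that single case, a small upward step is expected in this assay, and a reading at the limit is quite possible. The expected change is a 1.4-fold higher number from compound 2 to compound 4 (0.15 log units; within the scatter). Compound 4 is estimated at 65000 nM, with an expected range from 30000 nM to 130000 nM.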

Compound 4, half-maximal inhibitory concentration: > 50000 nM
Compound 4: no number, only a limit (the forecaster's own chance of this, stated with the estimate: 60%); the middle value is on the limit's open side.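

In this assay, compound 4 gives > 50000 nM, which is a limit of the assay and not a number. Among these compounds, compound 2 and compound 4 give a direct comparison at the aromatic nitrogen, which the earlier compounds did not offer, but the change from benzyl to hydrogen can be read only as a floor: an at least 1.0-fold higher number from compound 2 to compound 4 (0.03 log units; that floor lies within the scatter). With hydrogen on this nitrogen, neither compound 3 nor compound 4 gives a reading short of the limit, so neither shows any sign of stronger inhibition: the limit of > 50000 nM in this assay, at which 2 of the 4 values shown sit.

As far as these compounds go, how far the true reading of compound 4 lies past the limit remains open, and so does the real size of this step. Also open, from the compounds shown here alone, is how the reading would respond to a group other than benzyl or hydrogen on this nitrogen, such as an ethyl group or a longer chain ending in an amine.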